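Changing the Group on the Phenyl of Compound 3

A few compounds are considered here, and "the series" means these few. Any claim that something is new, unique, unknown or untested is made for them only; others in the source may bear on it.

In an assay for inhibition of inositol hexakisphosphate kinase 2 (Homo sapiens), read by colorimetric assay, coupled enzyme assay and malachite green, with a stated time of 120 min, in the presence of a further agent that is not named here (on this read-out lower numbers stand for stronger inhibition and higher numbers for weaker inhibition), compound 3 `O=C(O)c1ccc2noc(-c3ccc(Oc4ccccc4)cc3)c2c1` gives 280 nM, the lowest of the three numbers shown. Compound 2 `CNC(=O)c1ccc2noc(-c3ccccc3)c2c1` gives 2120 nM, and compound 1 `CN(C)C(=O)/C=C/c1ccc2noc(-c3ccccc3)c2c1` gives 40300 nM. Among the compounds with values here, the one step measured so far, a 19-fold lower number from compound 1 to compound 2 (1.28 log units; beyond the scatter), concerns a different position on the shared core and so says nothing direct about the change now in question. Compound 4 `O=C(O)c1ccc2noc(-c3ccc(NC(=O)c4ccncn4)cc3)c2c1` differs from compound 3 by ((pyrimidin-4-yl)carbonyl)amino in place of phenoxy on an aromatic carbon. Within the data shown here, since no measured step bears on this exchange, no step beyond the scatter is expected in this assay in either direction. The estimate for compound 4 is 300 nM, with a range from 60 nM to 1500 nM, which would mean a step of a 1.1-fold higher number from compound 3 to compound 4 (0.03 log units; within the scatter).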

Compound 4, half-maximal inhibitory concentration: 720 nM
The estimate for compound 4 lay 2.4-fold (0.38 log units) below the measured number; the range from low to high includes it.
By their numbers in this assay, from the lowest: compound 3; then compound 4; then compound 2; then compound 1.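

In this assay, ((pyrimidin-4-yl)carbonyl)amino in place of phenoxy gives a 2.6-fold higher number from compound 3 to compound 4 (0.41 log units; beyond the scatter). This is a real but modest change, so this position, on a six-membered aromatic ring of carbon only, tolerates an exchange of one ring-bearing group for another, even though the entering group adds a hydrogen-bond donor and a ring with 2 hetero atoms. Nothing available here explains the weaker inhibition.

Still open, going by these compounds, is how a small group such as an amine or methoxy would compare at this place. A benzoylamino group would show whether the ring nitrogens of the pyrimidine matter.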